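This account rests on a few compounds, and the source may have more. Where it says the series, first, only, none or still open, it means among the compounds named here.

Compound 1 `CCn1c(C(=O)N[C@@H](CO)C(C)C)ccc1C(CC)(CC)c1ccc(OCS(=O)(=O)c2ccccc2)c(C)c1`: 10600 nM
Compound 2 `CCN(CC)CCNC(=O)c1ccc(C(CC)(CC)c2ccc(OCSC)c(C)c2)n1CC`: 4010 nM

In a functional assay on PC-3 cells (Homo sapiens) for antiproliferative activity, read by MTT assay, with a stated time of 24 h (on this read-out lower numbers stand for stronger inhibition and higher numbers for weaker inhibition), compound 2 has the lower of the two numbers at 4010 nM, while compound 1 gives 10600 nM, a gap beyond the usual scatter. Compound 3 `CCN(CC)CCNC(=O)c1ccc(C(CC)(CC)c2ccc(OCS(C)(=O)=O)c(C)c2)n1CC` differs from compound 2 by methylsulfonyl in place of methylsulfanyl on a saturated chain carbon bound to an oxygen on an aromatic ring. Going by the values given here, no measured pair isolates this change, so only a modest rise in this assay is expected, towards weaker inhibition. The expected step is a 1.5-fold higher number from compound 2 to compound 3 (0.18 log units; within the scatter). Compound 3 is estimated at 6000 nM, with an expected range of 2500 nM to 14000 nM.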

Compound 3, half-maximal inhibitory concentration: 46700 nM
Compound 3: middle estimate off by 7.8-fold (0.89 log units), on the low side; the measured number lies above the stated range.
By their numbers in this assay, from the lowest: compound 2; then compound 1; then compound 3.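

Changing methylsulfanyl to methylsulfonyl on a saturated chain carbon bound to an oxygen on an aromatic ring gives in this assay a 12-fold higher number from compound 2 to compound 3 (1.07 log units; beyond the scatter) and thus a large loss of inhibition. With the rest of the molecule unchanged, this position is clearly sensitive to the group it carries. No measurement at hand explains this shift. On these data alone, how a methylsulfinyl or ethylsulfanyl group would read at this place remains open, as does whether the same step would appear with the amide side chain of compound 1.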